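The source may hold more compounds than are shown below. What is called first, only, known or untested is meant among the compounds shown, and "the series" means these compounds.

Measured in an ADME assay on MT4 cells (Homo sapiens) for cytotoxicity, read by MTT assay, with a stated time of 5 days; a higher number here means that more compound is tolerated, a lower number that less compound is tolerated:
Compound 1 `Cc1cccc(C)c1Oc1cc(Nc2ccc(C#N)cc2)[nH]c(=O)c1Br`: 63000 nM
Compound 2 `Cc1cccc(C)c1Oc1cc(Nc2ccc(C#N)cc2)[nH]c(=O)c1Cl`: 29000 nM
Compound 3 `Cc1cc(C#N)cc(C)c1Oc1cc(Nc2ccc(C#N)cc2)[nH]c(=O)c1I`: > 259000 nM

Compound 3 stands at > 259000 nM, which is a limit of this assay and not a number. Compound 4 `Cc1cccc(C)c1Oc1cc(Nc2ccc(C#N)cc2)[nH]c(=O)c1I` differs from it by hydrogen in place of cyano on an aromatic carbon. Going by the values given here, the only measured step, a 2.2-fold lower number from compound 1 to compound 2 (0.34 log units; beyond the scatter), swaps one halogen for another, so it bears on this change only indirectly. Still, it suggests that halogen swaps move this read-out modestly, and compounds 1 and 2 already carry hydrogen at that place. Compound 4 should therefore resemble them, with compound 1 at 63000 nM as the closest guide. A clearly lower number than for compound 3 is expected, an estimated at least 3.9-fold lower number from compound 3 to compound 4 (0.60 log units; beyond the scatter). Compound 4 is estimated at 65000 nM, with an expected range of 25000 nM to 170000 nM.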

Compound 4, half-maximal cytotoxic concentration: 28000 nM
Beside the measured number, compound 4's estimate is 2.3-fold (0.37 log units) above it, within the range that was stated.
By their numbers in this assay, from the lowest: compounds 4 and 2 (each within the scatter of the next); then compound 1. At a limit, above all of these: compound 3.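

Hydrogen in place of cyano on this aromatic carbon gives an at least 9.2-fold lower number from compound 3 to compound 4 (0.96 log units; beyond the scatter), a step read against a limit of the assay, not a number: the limit of > 259000 nM in this assay, at which 1 of the 4 values shown sits.

Among the iodo, bromo and chloro compounds, which all carry hydrogen at this place, iodo in place of chloro gives a 1.0-fold lower number from compound 2 to compound 4 (0.02 log units; within the scatter), and iodo in place of bromo gives a 2.3-fold lower number from compound 1 to compound 4 (0.35 log units; beyond the scatter). The cyano group therefore accounts for a larger step than either halogen swap.

On these data alone, it remains open how an amine or a methoxy group at this place would compare. Whether cyano gives a similar step in the bromo or chloro compounds is also unknown.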